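Dropping Both Methoxy Groups from the Bromoacrylamide Lead

The source may report more compounds than this note shows. Statements on the series, on what has been measured and on what is new or still open speak of the compounds shown alone.

Compound 1 `C=C(Br)C(=O)Nc1cccc(-c2cn3nc(-c4ccc(OC)c(OC)c4)sc3n2)c1` gives 610 nM in a functional assay on HeLa cells (Homo sapiens) for inhibition, read by cell counting, with a stated time of 4 days (on this read-out lower numbers stand for stronger inhibition and higher numbers for weaker inhibition), the lowest of the three numbers shown. Compound 2 `Nc1cccc(-c2cn3nc(Cc4ccc(Cl)cc4)sc3n2)c1` gives 25000 nM and compound 3 `Nc1cccc(-c2cn3nc(Cc4ccccc4)sc3n2)c1` gives 24000 nM; both carry an aniline and a benzyl group on the shared core, and the step of a 1.0-fold lower number from compound 2 to compound 3 (0.02 log units; within the scatter) stays within the scatter. Compound 4 `C=C(Br)C(=O)Nc1cccc(-c2cn3nc(-c4ccccc4)sc3n2)c1` differs from compound 1 by phenyl in place of 3,4-dimethoxyphenyl on an aromatic carbon. Within the data shown here, no measured pair removes methoxy groups, so the only guidance is that the single change on a pendant aromatic ring, from compound 2 to compound 3, left this assay essentially unmoved. A modest loss is therefore judged possible but far from certain. Compound 4 is expected to give 1200 nM, with a range of 400 nM to 4000 nM. The expected step is a 2.0-fold higher number from compound 1 to compound 4 (0.29 log units; within the scatter).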

Compound 4, half-maximal inhibitory concentration: 1400 nM
Beside the measured number, compound 4's estimate is 1.2-fold (0.07 log units) below it; measured number inside the range.
By their numbers in this assay, from the lowest: compound 1; then compound 4; then compounds 3 and 2 (each within the scatter of the next).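

At this aromatic carbon, next to the ring nitrogen and the ring sulfur, phenyl in place of 3,4-dimethoxyphenyl gives a 2.3-fold higher number from compound 1 to compound 4 (0.36 log units; beyond the scatter) in this assay. Unlike the step of a 1.0-fold lower number from compound 2 to compound 3 (0.02 log units; within the scatter) on a pendant aromatic ring, this modest step lies beyond the scatter, so removing both methoxy groups has a small but readable effect on this read-out. Nothing shown accounts for this step.

The compounds shown leave open whether a single methoxy group would match compound 1 or compound 4. They also leave open how an amine or a carboxylic acid on this phenyl ring would read.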